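The source may hold more compounds than are shown below. What is called first, only, known or untested is meant among the compounds shown, and "the series" means these compounds.

Measured so far:
- compound 1, `C=CC(=O)Nc1cccc(Nc2ncnc(Nc3ccc(OC)cc3)n2)c1`: 14500 nM
- compound 2, `C/C=C/C(=O)Nc1cccc(Nc2ncnc(Nc3ccc(C(=O)N4CCCCC4)cc3)n2)c1`: 13800 nM
- compound 3, `C=CC(=O)Nc1cccc(Nc2nc(Cl)nc(Nc3ccc(Oc4ccccc4)cc3)n2)c1`: 15700 nM

In a functional assay on Raji cells (Homo sapiens) for antiproliferative activity, read by CCK-8 assay, with a stated time of 24 h (on this read-out higher numbers stand for weaker inhibition and lower numbers for stronger inhibition), compound 1 gives 14500 nM. Among the three numbers compound 1 stands second highest, yet its gaps to compound 2 and to compound 3 both lie within the scatter, so the three compounds cannot be told apart on this read-out.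

Compound 4, `C=CC(=O)Nc1cccc(Nc2ncnc(Nc3ccc(OCCOC)cc3)n2)c1`, is not yet measured. It differs from compound 1 in one place: methoxymethyl in place of hydrogen on a saturated chain carbon bound to an oxygen on an aromatic ring. The methoxy group of compound 1 thereby becomes a 2-methoxyethoxy group.

Going by the values given here, no measured pair shows what such a change does here. Given that all three measured compounds sit close together, the step from compound 1 to compound 4 is expected to be small, a 1.0-fold lower number from compound 1 to compound 4 (0.02 log units; within the scatter), with no direction beyond the scatter. Compound 4 is therefore estimated at 14000 nM, within 6000 nM to 35000 nM.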

Compound 4, half-maximal inhibitory concentration: 105000 nM
Compound 4: the middle estimate sits 7.5-fold (0.88 log units) below what was measured; measured number outside the range, above it.
By their numbers in this assay, from the lowest: compounds 2, 1 and 3 (each within the scatter of the next); then compound 4.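

Replacing methoxy with 2-methoxyethoxy gives a 7.2-fold higher number from compound 1 to compound 4 (0.86 log units; beyond the scatter) in this assay, so inhibition becomes weaker. The three earlier compounds sat too close together to show that this position responds to change, but a single added methoxymethyl group is enough to make a clear difference here. No measurement available here explains this loss.

As far as these compounds go, whether the loss comes with chain length or with the added oxygen remains open. An ethoxy group, a propoxy group or a chain ending in an amine could help separate these possibilities.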